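Ring Enlargement at the Aromatic Carbon of Compound 2

This account rests on a few compounds, and the source may have more. Where it says the series, first, only, none or still open, it means among the compounds named here.

Of the compounds shown here, three of one shared core have been tested in an ADME assay on MDCK cells (Canis lupus familiaris) for cytotoxicity, read by microscopy, with a stated time of 48 h; a lower number here means that less compound is tolerated, a higher number that more compound is tolerated. Compound 1 `C[C@H]1[C@H](NCc2ccoc2)C[C@H]2C[C@@H]1C2(C)C` gives only a limit there, > 100000 nM, the mark described by the limit of > 100000 nM in this assay, at which 1 of the 3 values shown sits. Compound 2 `C[C@H]1[C@H](NCc2cc(C3CC3)cs2)C[C@H]2C[C@@H]1C2(C)C` gives 25000 nM in this assay, the lowest of the two numbers recorded. Compound 3 `CCOc1ccsc1CN[C@@H]1C[C@H]2C[C@@H]([C@H]1C)C2(C)C` gives 50000 nM in this assay, which lies within the scatter of the value of compound 2. Compound 4 `C[C@H]1[C@H](NCc2cc(C3CCCC3)cs2)C[C@H]2C[C@@H]1C2(C)C` has not been measured; it differs from compound 2 by cyclopentyl in place of cyclopropyl on an aromatic carbon. For the measured compounds named here, no step between measured compounds is available to guide the expectation, so the change can only be judged as small. In this assay compound 4 is expected at 15000 nM, within a range from 5000 nM to 50000 nM. The expected step of a 1.7-fold lower number from compound 2 to compound 4 (0.22 log units; within the scatter) is a modest lowering, at the edge of the scatter.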

Compound 4, minimum cytotoxic concentration: 1560 nM
Beside the measured number, compound 4's estimate is 9.6-fold (0.98 log units) above it; the whole stated range lies above it.
By their numbers in this assay, from the lowest: compound 4; then compounds 2 and 3 (each within the scatter of the next). At a limit, above all of these: compound 1.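

In this assay, the aromatic carbon two ring bonds from the ring sulfur proves to be a place where the group matters: cyclopentyl in place of cyclopropyl gives a 16-fold lower number from compound 2 to compound 4 (1.20 log units; beyond the scatter), a large step. Neither group carries hydrogen-bond donors, hydrogen-bond acceptors or a net charge, so a swap between two carbon-only rings is enough to move the number this far. Nothing shown here gives a cause for the step. Going by these compounds, what cyclobutyl, a longer chain or an amine would give on this carbon remains open, and so does whether the number follows ring size at all.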